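Neopentyl in place of fluorophenyl on the shared core

This account rests on a few compounds, and the source may have more. Where it says the series, first, only, none or still open, it means among the compounds named here.

Among the measured compounds shown here, compound 2 `O=C(O)c1ccccc1-c1ccc(CCc2ncc(Cc3cccc(F)c3)[nH]2)cc1` is the one compound with a number in an in vitro functional assay on cells for agonist activity at Bombesin receptor subtype-3 (Mus musculus), read by luminescence and calcium flux; a higher number here means that more compound is needed for the effect, a lower number that less compound is needed: it gives 7.9 nM. Compound 1 `CCCCc1cnc(Cc2ccc(-c3ccccc3C(=O)O)cc2)[nH]1` is known only by a limit of the assay, > 10000 nM, and the limit of > 10000 nM in this assay, at which 1 of the 2 values shown sits, marks where it sits. For the measured compounds named here, compound 1 and compound 2 differ in more than one place, so no single step between them is counted.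

Compound 3 `CC(C)(C)CCc1cnc(CCc2ccc(-c3ccccc3C(=O)O)cc2)[nH]1` has not yet been measured. It differs from compound 2 by neopentyl in place of 3-fluorophenyl on a saturated chain carbon bound to an aromatic carbon. Going by the values given here, no measured pair shows a change of this kind, so there is no step to lean on.

The expected step from compound 2 to compound 3 in this assay is an increase, a 25-fold higher number from compound 2 to compound 3 (1.40 log units; beyond the scatter), and this estimate rests only on the value of compound 2, 7.9 nM. The estimate for compound 3 in this assay is 200 nM, expected to fall between 30 nM and 3000 nM.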

Compound 3, half-maximal effective concentration: 6.2 nM
For compound 3 the middle estimate is 32-fold (1.51 log units) above the measured one; the measured number lies below the stated range.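

Putting neopentyl in place of 3-fluorophenyl leaves the two compounds level in this assay (a 1.3-fold lower number from compound 2 to compound 3 (0.11 log units; within the scatter)), so on this saturated chain carbon bound to an aromatic carbon, the six-membered aromatic ring and the fluorine of compound 2 are not needed to keep the value. This is the first step shown at this position, and it pairs a group with no ring with a ring-bearing group without any separation beyond the scatter. Nothing shown here accounts for this equivalence.

From the compounds shown here alone, a single step cannot show how far this tolerance extends, and whether a shorter chain such as ethyl, or an amine or a carboxylic acid at the end of the chain, would keep the value remains open. Going by these compounds, it also remains open whether the same exchange would behave alike on a different core.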